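From 4-chlorophenyl to 2-chlorophenyl on compound 2

The source may report more compounds than this note shows. Statements on the series, on what has been measured and on what is new or still open speak of the compounds shown alone.

Of the compounds shown here, two have been read so far in a functional assay on MCF7 cells (Homo sapiens) for cytotoxicity, read by MTT assay, with a stated time of 72 h; a lower number here means a stronger inhibitor, a higher number a weaker inhibitor. Going by the values given here, compound 2 `O=C(CCl)Nc1ccc(C(=O)/C=C/c2ccc(Cl)cc2)cc1` gives 4100 nM, the only true number available. Compound 1 `CCCCCCSC(=S)N[C@H]1CCOC1=O` reaches only a limit, > 128000 nM. Among the compounds with values here, with no number for compound 1, there is no measured gap to compound 2 and no measured step to work from.

The next compound is compound 3 `O=C(CCl)Nc1ccc(C(=O)/C=C/c2ccccc2Cl)cc1`. It keeps the rest of compound 2 and carries 2-chlorophenyl in place of 4-chlorophenyl on a double-bonded chain carbon bound to a double-bonded chain carbon. The two compounds have the same atoms, joined differently.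

Within the data shown here, no earlier pair shows what this exchange does, so the expectation rests only on compound 2 at 4100 nM and on the closeness of the two structures. In this assay, no change beyond the usual scatter is expected, and no direction is favoured with any confidence. The estimated step is a 1.0-fold lower number from compound 2 to compound 3 (0.01 log units; within the scatter). For compound 3 the expected value is 4000 nM, with an estimated range from 1600 nM to 10000 nM.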

Compound 3, half-maximal inhibitory concentration: 5260 nM
For compound 3 the middle estimate is 1.3-fold (0.12 log units) below the measured one; the measured number falls inside the stated range.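

In this assay, going by these compounds alone, the exchange of 4-chlorophenyl for 2-chlorophenyl on a double-bonded chain carbon bound to a double-bonded chain carbon gives a 1.3-fold higher number from compound 2 to compound 3 (0.11 log units; within the scatter) and provides the first readable step. For this pair, the assay does not separate the two chlorophenyl groups at this place, so moving the chlorine between these two ring positions leaves the read-out within what repeated measurements would show. No measured property in hand bears on this result.

Still open, as far as these compounds go, is whether this tolerance extends beyond chlorine, since 3-chlorophenyl, unsubstituted phenyl, or a phenyl ring carrying a methoxy group or an amine at the same place could read differently from compound 2 and compound 3. Also open, from the compounds shown here alone, is the contribution of the rest of the shared core, where an acetyl group in place of the chloroacetyl group on the amide nitrogen would test whether that chlorine matters to the read-out.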